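The source may report more compounds than this note shows. Statements on the series, on what has been measured and on what is new or still open speak of the compounds shown alone.

Compound 1 `CCCN(CC[C@H]1CC[C@H](NC(=O)/C=C/c2cccc(F)c2)CC1)[C@H]1CCc2nc(N)sc2C1` gives 9.9 nM in an assay on brain for displacement of a labelled ligand from D(3) dopamine receptor (Rattus norvegicus) (a lower number here means a stronger inhibitor, a higher number a weaker inhibitor), the highest of the three numbers recorded, though its gap to compound 2 is within the scatter. Compound 2 `CCCN(CC[C@H]1CC[C@H](NC(=O)/C=C/c2ccccc2OC)CC1)[C@H]1CCc2nc(N)sc2C1` gives 8.1 nM in this assay, and the step of a 1.2-fold lower number from compound 1 to compound 2 (0.09 log units; within the scatter) is within the scatter. Compound 3 `CCCN(CC[C@H]1CC[C@H](NC(=O)c2cccc3ncccc23)CC1)[C@H]1CCc2nc(N)sc2C1` gives 1.6 nM in this assay, reached through a 6.2-fold lower number from compound 1 to compound 3 (0.79 log units; beyond the scatter) and likewise through a 5.1-fold lower number from compound 2 to compound 3 (0.70 log units; beyond the scatter), both beyond the scatter. The untested compound 4 `CCCN(CC[C@H]1CC[C@H](NC(=O)c2ccc(-n3cccn3)cc2)CC1)[C@H]1CCc2nc(N)sc2C1` differs from compound 1 at a single place: 4-(1H-pyrazol-1-yl)phenyl in place of 2-(3-fluorophenyl)ethenyl on a carbonyl carbon. The measured steps that bear on this change are those in which a 2-arylethenyl group on the carbonyl carbon gave way to an aromatic group bound directly to that carbon, namely a 6.2-fold lower number from compound 1 to compound 3 (0.79 log units; beyond the scatter) and a 5.1-fold lower number from compound 2 to compound 3 (0.70 log units; beyond the scatter); both were modest lowerings. Among the compounds with values here, no measured compound carries the 4-(1H-pyrazol-1-yl)phenyl group itself, and quinolin-5-yl is a different group, so the size of the step for compound 4 is less certain than its direction. One therefore expects a lowering of the number from compound 1 to compound 4, a 2.8-fold lower number from compound 1 to compound 4 (0.45 log units; beyond the scatter), of modest size. Compound 4 is estimated at 3.5 nM in this assay, with an expected range from 1.2 nM to 10 nM.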

Compound 4, inhibition constant: 3 nM
Compound 4: middle estimate off by 1.2-fold (0.07 log units), on the high side; low and high end bracket the measured number.
By their numbers in this assay, from the lowest: compounds 3 and 4 (each within the scatter of the next); then compounds 2 and 1 (each within the scatter of the next).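

Compound 4 shows that the lowering seen on leaving a 2-arylethenyl group for an aromatic group bound directly to the carbonyl carbon is not confined to quinolin-5-yl: in this assay the change to 4-(1H-pyrazol-1-yl)phenyl gives a 3.3-fold lower number from compound 1 to compound 4 (0.52 log units; beyond the scatter) and also a 2.7-fold lower number from compound 2 to compound 4 (0.43 log units; beyond the scatter). The two directly bound groups cannot be told apart at this position, as a 1.9-fold higher number from compound 3 to compound 4 (0.27 log units; within the scatter) stays within the scatter even though the entering group brings a five-membered aromatic ring with 2 hetero atoms. Among these four compounds, both with a directly bound aromatic group therefore lie beyond the scatter below both with a 2-arylethenyl group, and none goes against this split.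

The compounds shown leave open whether the lowering goes with the loss of the double bond outside aromatic rings or with the aromatic groups that enter, a question that a 2-(3-fluorophenyl)ethyl group or a plain phenyl group on the carbonyl carbon would help to separate. No supporting evidence is available to account for the differences among these compounds.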